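Removing a methoxy group from an acid-bearing quinoline amide

The source may hold more compounds than are shown below. What is called first, only, known or untested is meant among the compounds shown, and "the series" means these compounds.

Of the compounds shown here, three share one core and have been tested in a functional assay on Hep 3B2 cells (Homo sapiens) for antiproliferative activity, read by MTT assay, with a stated time of 24 h, tested at 0.02 ug/mL; a higher number here means a stronger effect of the compound at the concentration tested, a lower number a weaker effect. Compound 1 `COc1ccc2nc(C(=O)Nc3ccc(-c4ccccc4)cc3)c(C)c(O)c2c1` gives 0.96%. Compound 2 `Cc1c(C(=O)Nc2ccc(-c3ccccc3)cc2)nc2ccccc2c1O` gives 1.05%. Compound 3 `COc1ccc2nc(C(=O)Nc3ccc(-c4ccccc4)cc3)c(C)c(C(=O)O)c2c1` gives 0.05%. Going by the values given here, all three numbers lie close together: the step of a number 0.9 percentage points lower from compound 1 to compound 3 (within the scatter) is within the scatter, and the gap between compound 3 and compound 2 is equally small, so no compound can be called stronger or weaker than another on this evidence.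

Compound 4 `Cc1c(C(=O)Nc2ccc(-c3ccccc3)cc2)nc2ccccc2c1C(=O)O` is not yet measured. It differs from compound 3 by hydrogen in place of methoxy on an aromatic carbon.

The same exchange has already been seen once, on the step of a number 0.1 percentage points higher from compound 1 to compound 2 (within the scatter), which stayed within the scatter. Among the compounds with values here, since that is the only guide, the expectation for compound 4 in this assay is that the number stays near zero, with a step of about a number 0.1 percentage points higher from compound 3 to compound 4 (within the scatter) from compound 3, not beyond the scatter. Compound 4 is therefore estimated at 0.1%, in a range from -4% to 5%.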

Compound 4, a percentage reported as inhibition, at one concentration (the size of the read-out at that concentration, not a potency): -0.35%
Estimate against measurement, compound 4: 0.5 percentage points above; measured number inside the range.
By their numbers in this assay, from the lowest: compounds 4, 3, 1 and 2 (each within the scatter of the next).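

Removing the methoxy group from the acid-bearing core gives a step that can be read alongside its earlier counterpart, a number 0.4 percentage points lower from compound 3 to compound 4 (within the scatter) in this assay, so this change has now been seen on two cores and is within the scatter on both: the same change on two cores in this assay, a number 0.1 percentage points higher (within the scatter) from compound 1 to compound 2 and a number 0.4 percentage points lower (within the scatter) from compound 3 to compound 4, 0.5 percentage points apart, within the scatter of two such steps. The exchange of hydroxy for carboxy can also now be read on the core without methoxy, with a number 1.4 percentage points lower from compound 2 to compound 4 (within the scatter), and it matches the step on the methoxy core: the same change on two cores in this assay, a number 0.9 percentage points lower (within the scatter) from compound 1 to compound 3 and a number 1.4 percentage points lower (within the scatter) from compound 2 to compound 4, 0.5 percentage points apart, within the scatter of two such steps. Neither change lifts any of the four compounds clear of the others on either core.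

With all four numbers close to zero at one concentration, these compounds cannot show whether this position matters for a compound with a clear effect. On these data alone, whether an amine or a longer chain at this position would give a number beyond the scatter remains open.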